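Benzylidene thiazolidinedione series: N-substituent variation

A few compounds are considered here, and "the series" means these few. Any claim that something is new, unique, unknown or untested is made for them only; others in the source may bear on it.

Measured compounds:
compound 1 `COc1cc(-c2nc3cc(/C=C4\SC(=O)N(CC(=O)N5CCCC5)C4=O)ccc3[nH]2)cc(OC)c1OC` 8370 nM
compound 2 `COc1cc(-c2nc3cc(/C=C4\SC(=O)N(Cc5ccccc5)C4=O)ccc3[nH]2)cc(OC)c1OC` 2500 nM
compound 3 `COc1cc(-c2nc3cc(/C=C4\SC(=O)N(Cc5cccc(C)c5)C4=O)ccc3[nH]2)cc(OC)c1OC` 4370 nM

In a functional assay on PC-3 cells (Homo sapiens) for inhibition, read by MTT assay, with a stated time of 48 h (a lower number here means a stronger inhibitor, a higher number a weaker inhibitor), compound 3 sits second highest of the three numbers; its nearest neighbour is compound 2 and its furthest is compound 1, and both of those gaps are within the scatter. The next compound, compound 4 `COc1cc(CN2C(=O)S/C(=C\c3ccc4[nH]c(-c5cc(OC)c(OC)c(OC)c5)nc4c3)C2=O)cc(OC)c1OC`, differs from compound 3 by 3,4,5-trimethoxyphenyl in place of 3-methylphenyl on a saturated chain carbon bound to an amide-type nitrogen in a ring.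

Among the measured compounds shown here, three measured steps touch this position. The step of a 3.3-fold lower number from compound 1 to compound 2 (0.52 log units; beyond the scatter) was the only one beyond the scatter, whereas a 1.9-fold lower number from compound 1 to compound 3 (0.28 log units; within the scatter) and a 1.7-fold higher number from compound 2 to compound 3 (0.24 log units; within the scatter) both stayed within it. For the measured compounds named here, the step to compound 4 keeps an aromatic ring on the saturated chain carbon and changes only what that ring carries; the one measured change of that sort, from compound 2 to compound 3, gave nothing beyond the scatter. Nothing measured speaks to a methoxy-bearing ring at this place, so the expectation is a step of a 1.1-fold lower number from compound 3 to compound 4 (0.04 log units; within the scatter) of no real size. Compound 4 is estimated at 4000 nM in this assay, with a range from 1500 nM to 12000 nM.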

Compound 4, half-maximal inhibitory concentration: 10200 nM
Estimate against measurement, compound 4: 2.6-fold (0.41 log units) below, and the stated range covers the measured number.
By their numbers in this assay, from the lowest: compounds 2, 3, 1 and 4 (each within the scatter of the next, the first and the last beyond it).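

In this assay, among the compounds shown here, the aromatic ring on the saturated chain carbon proves sensitive to what it carries: 3,4,5-trimethoxyphenyl in place of 3-methylphenyl gives a 2.3-fold higher number from compound 3 to compound 4 (0.37 log units; beyond the scatter) and in place of phenyl gives a 4.1-fold higher number from compound 2 to compound 4 (0.61 log units; beyond the scatter) as the first changes of ring substitution here to lie beyond the scatter. An aromatic ring at this place therefore holds no general edge over (pyrrolidin-1-yl)carbonyl, since a 1.2-fold higher number from compound 1 to compound 4 (0.09 log units; within the scatter) stays within the scatter, unlike the earlier step from that group to phenyl. No supporting data bear on the reason for these steps.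

Open, from the compounds shown here alone, is whether the change follows the three methoxy groups together or any single one of them. Also open, going by these compounds, is how a dimethylamino group or a carboxylic acid on that ring would read at this place.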